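This account rests on a few compounds, and the source may have more. Where it says the series, first, only, none or still open, it means among the compounds named here.

In a functional assay for inhibition, with Homo sapiens as the target (a lower number here means a stronger inhibitor, a higher number a weaker inhibitor), three compounds have been measured. Compound 1 `O=C(O)CCCCCCn1nc(-c2ccccc2)c(-c2ccccc2)c1-c1ccccc1` gives 22400 nM. Compound 2 `O=C(O)CCCCCCCCn1nc(-c2ccccc2)c(-c2ccccc2)c1-c1ccccc1` gives 400 nM, the lowest of the two numbers. Compound 3 `O=C(O)CCCCCCCn1cc(-c2ccccc2)c(-c2ccccc2)n1` gives only a limit of the assay, > 85000 nM. Among the measured compounds shown here, the one step between measured compounds that differ in a single place is a 56-fold lower number from compound 1 to compound 2 (1.75 log units; beyond the scatter), a change of chain length. Compound 4 `N#CCCCCCCCCn1nc(-c2ccccc2)c(-c2ccccc2)c1-c1ccccc1` differs from compound 2 by cyano in place of carboxy on a saturated chain carbon, eight bonds along the chain from an aromatic nitrogen. For the measured compounds named here, no measured step alters the carboxy group itself, so the lengthening step is not a direct guide. A weaker inhibitor is nevertheless expected, and the expected step is a 7.5-fold higher number from compound 2 to compound 4 (0.88 log units; beyond the scatter). Compound 4 is therefore estimated at 3000 nM, between 400 nM and 25000 nM.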

Compound 4, half-maximal inhibitory concentration: > 72000 nM
Compound 4 ended at the assay's limit; the forecaster's own chance of this, stated with the estimate: 15%; at least 24-fold (1.38 log units) between middle value and limit.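

At this chain end the carboxy group cannot be replaced by cyano without a heavy loss: the change gives an at least 180-fold higher number from compound 2 to compound 4 (2.25 log units; beyond the scatter). The longer chain alone does not carry the activity, since the shorter-chained acid still does better, with an at least 3.2-fold higher number from compound 1 to compound 4 (0.50 log units; beyond the scatter). The value of compound 4 is a limit of the assay and not a number, so both steps are minimum sizes: the limit of > 72000 nM in this assay, at which 1 of the 4 values shown sits.

Cyano differs from carboxy in more than its missing hydrogen-bond donor, so the compounds shown cannot say which difference matters. A primary amide or a methyl ester at the same chain end would help to separate these differences.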